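Removing a methyl group on a fused thiazole-type core

The source may report more compounds than this note shows. Statements on the series, on what has been measured and on what is new or still open speak of the compounds shown alone.

Compound 1 `CSc1nc2c(C)nsc2[nH]1` and compound 2 `CSc1nc2cnsc2[nH]1` share a core; compound 3 `Cc1nsc2[nH]c(SCc3ccccc3)nc12` and compound 4 `c1ccc(CSc2nc3cnsc3[nH]2)cc1` share another, and the difference between the two cores is not broken down here. In a functional assay on KB cells (Homo sapiens) for antiproliferative activity (on this read-out higher numbers stand for weaker inhibition and lower numbers for stronger inhibition), compound 1 gives 60000 nM, compound 2 gives 15000 nM, and compound 3 gives 9000 nM. The change from compound 1 to compound 2 is hydrogen in place of methyl on an aromatic carbon, and it gave a 4.0-fold lower number from compound 1 to compound 2 (0.60 log units; beyond the scatter). The change from compound 3 to compound 4 is hydrogen in place of methyl on an aromatic carbon, the same change at the same place on a different core. Because the earlier step of a 4.0-fold lower number from compound 1 to compound 2 (0.60 log units; beyond the scatter) was beyond the scatter, a similar step is expected for compound 4, namely a 3.0-fold lower number from compound 3 to compound 4 (0.48 log units; beyond the scatter). Compound 4 is therefore estimated at 3000 nM, somewhere between 1200 nM and 7500 nM.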

Compound 4, half-maximal inhibitory concentration: 200 nM
For compound 4 the middle estimate is 15-fold (1.18 log units) above the measured one; measured number below the stated range.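

In this assay, hydrogen in place of methyl on an aromatic carbon gave a 45-fold lower number from compound 3 to compound 4 (1.65 log units; beyond the scatter). The direction of the change carried over from one core to the other, but its size did not: the same change on two cores in this assay, a 4.0-fold lower number (0.60 log units; beyond the scatter) from compound 1 to compound 2 and a 45-fold lower number (1.65 log units; beyond the scatter) from compound 3 to compound 4, 11-fold (1.05 log units) apart, beyond the scatter of two such steps. Going by these compounds alone, with only two cores, this does not show what sets the size of the step, so the earlier step alone would be a poor guide to its size on a further core.

The compounds shown leave open how an amine or a longer chain such as propyl would compare with hydrogen and methyl at this place. They also leave open which part of the difference between the two cores goes with the larger step.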